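Taking the (cyanomethyl)carbonyl group off compound 2

The source may hold more compounds than are shown below. What is called first, only, known or untested is meant among the compounds shown, and "the series" means these compounds.

In a functional assay on NCI-H460 cells (Homo sapiens) for inhibition, read by MTT assay (a higher number here means a weaker inhibitor, a lower number a stronger inhibitor), compound 2 (`CCOC(=O)c1c(NC(=O)CC#N)sc(C(=O)Nc2ccc(Cl)cc2)c1-c1ccccc1`) reads 430 nM as its value. That number cannot be told apart from compound 1 (`N#Cc1c(N)sc(C(=O)Nc2ccc(Cl)cc2)c1-c1ccccc1`) at 760 nM within the usual scatter, but it does lie under compound 3 (`N#CCC(=O)Nc1sc(C(=O)Nc2ccc(Cl)cc2)c(-c2ccccc2)c1C#N`) at 1040 nM by a modest margin.

Compound 4 (`CCOC(=O)c1c(N)sc(C(=O)Nc2ccc(Cl)cc2)c1-c1ccccc1`) differs from compound 2 in one place, with hydrogen in place of (cyanomethyl)carbonyl on a nitrogen on an aromatic ring as the whole change.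

The closest evidence is the same change run in reverse on the compounds that carry cyano instead of ethoxycarbonyl. Adding the group there gives a 1.4-fold higher number from compound 1 to compound 3 (0.14 log units; within the scatter) as a small step. The other measured step, a 2.4-fold higher number from compound 2 to compound 3 (0.38 log units; beyond the scatter) for short, swaps ethoxycarbonyl for cyano, so it is a different change and says only how far apart those two compounds sit. From the compounds shown here alone, a single pair is thin support, and it is untested whether the cyano result carries over to ethoxycarbonyl.

Read backwards, that pair points to a slightly lower number, but no step beyond the scatter is expected in this assay for this change. The expected result is a 1.3-fold lower number from compound 2 to compound 4 (0.10 log units; within the scatter) and no more. Compound 4 is therefore estimated at 340 nM with 150 nM to 750 nM as the expected range of a measurement.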

Compound 4, half-maximal inhibitory concentration: 380 nM
The estimate for compound 4 lay 1.1-fold (0.05 log units) below the measured number; measured number inside the range.
By their numbers in this assay, from the lowest: compounds 4, 2, 1 and 3 (each within the scatter of the next, the first and the last beyond it).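

Taking the (cyanomethyl)carbonyl group off the nitrogen gives a 1.1-fold lower number from compound 2 to compound 4 (0.05 log units; within the scatter), so in this assay the group now makes no readable difference on the ethoxycarbonyl compounds, where the earlier compounds had shown this only for the cyano pair: the same change on two cores in this assay, a 1.4-fold higher number (0.14 log units; within the scatter) from compound 1 to compound 3 and a 1.1-fold higher number (0.05 log units; within the scatter) from compound 4 to compound 2, 1.2-fold (0.08 log units) apart, within the scatter of two such steps Compound 4 also gives a second reading of the swap at the neighbouring aromatic carbon, this time with a plain amino group on the nitrogen, and ethoxycarbonyl in place of cyano gives a 2.0-fold lower number from compound 1 to compound 4 (0.30 log units; within the scatter). That step lies within the scatter while the earlier one lay beyond it, yet the two do not truly disagree, and the swap behaves alike whichever group the nitrogen carries: the same change on two cores in this assay, a 2.4-fold higher number (0.38 log units; beyond the scatter) from compound 2 to compound 3 and a 2.0-fold higher number (0.30 log units; within the scatter) from compound 4 to compound 1, 1.2-fold (0.08 log units) apart, within the scatter of two such steps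

The compounds shown carry only hydrogen and (cyanomethyl)carbonyl on this nitrogen, so it remains open whether an acetyl group, a benzoyl group or a longer chain there would prove just as silent. At the aromatic carbon, only cyano and ethoxycarbonyl appear, which leaves a carboxylic acid or a simple amide there as an open question.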